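Vero cell toxicity notes: from compound 3 to compound 4

A few compounds are considered here, and "the series" means these few. Any claim that something is new, unique, unknown or untested is made for them only; others in the source may bear on it.

Measured so far:
Compound 1, `O=C(N/N=C/c1c(-c2cc3ccccc3oc2=O)[nH]c2ccccc12)c1ccccc1`, in a toxicity assay on Vero cells (Chlorocebus sabaeus) for inhibition, read by MTT assay, with a stated time of 48 h (a lower number here means a stronger inhibitor, a higher number a weaker inhibitor), gives 121000 nM.
Compound 2, `O=C(N/N=C/c1c(-c2cc3ccccc3oc2=O)[nH]c2ccccc12)c1ccc(Cl)cc1`, in this assay gives > 200000 nM, which is a limit of the assay rather than a number.
Compound 3, `O=C(N/N=C/c1c(-c2cc3ccccc3oc2=O)[nH]c2ccccc12)c1cccc(Br)c1`, in this assay gives > 200000 nM, again a limit and not a number.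

Compound 3 therefore stands only at a limit, the one described by the limit of > 200000 nM in this assay, at which 2 of the 3 values shown sit, and the same limit holds for one further value in the set. The steps that reach it are an at least 1.6-fold higher number from compound 1 to compound 3 (0.21 log units; that floor lies within the scatter) and, for the other halogen, an at least 1.6-fold higher number from compound 1 to compound 2 (0.21 log units; that floor lies within the scatter); between the two halogenated compounds the step is a step that the two limits leave unreadable from compound 2 to compound 3.

Compound 4, `O=C(N/N=C/c1c(-c2cc3ccccc3oc2=O)[nH]c2ccccc12)c1ccc(Cl)cc1F`, is not yet measured. Its difference from compound 3 is 4-chloro-2-fluorophenyl in place of 3-bromophenyl on a carbonyl carbon. Among the measured compounds shown here, the only measured steps that bear on this change are the two halogen-for-hydrogen steps, both of which run toward the limit and leave no readable size, so no direction beyond the scatter can be read for the new substitution, and the most likely outcome is that compound 4 also lands at the limit.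

Compound 4 is expected to give 200000 nM, with a range from 100000 nM to 400000 nM. The expected step is a number no higher from compound 3 to compound 4 (the limit leaves the size open), which is within the scatter.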

Compound 4, half-maximal inhibitory concentration: > 200000 nM
Compound 4 gave a limit, no number; the forecaster's own chance of this, stated with the estimate: 65%; the middle value sits exactly at the limit.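

In this assay compound 4 gives > 200000 nM, a limit and not a number. The one readable step is an at least 1.6-fold higher number from compound 1 to compound 4 (0.21 log units; that floor lies within the scatter), and it shows that the 4-chloro-2-fluorophenyl group on the carbonyl carbon, carrying two halogens rather than one, still gives no readable number, so every halogen-bearing compound shown shares one limit: the limit of > 200000 nM in this assay, at which 3 of the 4 values shown sit. The steps to compound 4 from compound 2 and from compound 3 cannot be read, so neither the added fluoro nor the exchange of the 3-bromophenyl group has a size here.

On these data alone, how far compound 2, compound 3 and compound 4 lie from one another remains open. Also open, as far as these compounds go, is whether an amine or a carboxylic acid on this phenyl ring would give a readable number, as compound 1 does with 121000 nM.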